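This account rests on a few compounds, and the source may have more. Where it says the series, first, only, none or still open, it means among the compounds named here.

Measured so far in a functional assay on HeLa cells (Homo sapiens) for inhibition, read by MTT assay, with a stated time of 72 h; a higher number here means a weaker inhibitor, a lower number a stronger inhibitor:

- compound 1, `CN(C(=O)NC(=O)c1ccc(Cl)cc1Cl)c1nc(C(F)(F)F)c(C(=O)N/N=C/c2ccc(C(F)(F)F)cc2)s1`: 7.99 ug/mL
- compound 2, `CNc1nc(C)c(C(=O)N/N=C/c2cccc(C(F)(F)F)c2)s1`: a limit, > 100 ug/mL
- compound 3, `CNc1nc(C(F)(F)F)c(C(=O)N/N=C/c2cccc(C(F)(F)F)c2)s1`: a limit, > 100 ug/mL

Within the data shown here, compound 1 gives the only number in this assay; the other two values sit at the limit of > 100 ug/mL in this assay, at which 2 of the 3 values shown sit. For compound 2 the value is a limit of the assay, not a number. For compound 3 the value is likewise a limit.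

The change methyl in place of trifluoromethyl on an aromatic carbon gives the step that the two limits leave unreadable from compound 3 to compound 2, which the two limits leave unreadable. The same kind of change is made from compound 1 to compound 4, `Cc1nc(N(C)C(=O)NC(=O)c2ccc(Cl)cc2Cl)sc1C(=O)N/N=C/c1ccc(C(F)(F)F)cc1`, as methyl in place of trifluoromethyl on an aromatic carbon. The two place lines differ only in what the ring atom two ring bonds away bears: a methylamino group in the pair compound 3 and compound 2, a large group in the pair compound 1 and compound 4, so this is the same kind of change rather than the same one. The difference between the core of compound 1 and the core of compound 3 is not broken down here.

Among the measured compounds shown here, the only guide for compound 4 is a step that the two limits leave unreadable from compound 3 to compound 2, which cannot be read, so the step of a 1.5-fold higher number from compound 1 to compound 4 (0.18 log units; within the scatter) is expected to stay small. For compound 4 the estimate in this assay is 12 ug/mL, with a range from 4 ug/mL to 40 ug/mL.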

Compound 4, half-maximal inhibitory concentration: 20.3 ug/mL
For compound 4 the middle estimate is 1.7-fold (0.23 log units) below the measured one, and the stated range covers the measured number.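

In this assay, methyl in place of trifluoromethyl on an aromatic carbon gives a 2.5-fold higher number from compound 1 to compound 4 (0.40 log units; beyond the scatter), so on the core of compound 1 this change has a readable size and both compounds keep a measured number. The same kind of change on the core carrying the methylamino group, from compound 3 to compound 2, cannot be read, since both values are limits of the assay and not numbers: the limit of > 100 ug/mL in this assay, at which 2 of the 4 values shown sit. This leaves a single readable step, which shows what the change does on the core of compound 1 but does not show whether that size carries over to another core.

The compounds shown leave open how other groups on the same aromatic carbon compare with methyl and trifluoromethyl, such as an ethyl chain, a chlorine atom or a nitrile. They also leave open whether an amine or a carboxylic acid at that carbon would keep a measurable number on the core of compound 1.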